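This account rests on a few compounds, and the source may have more. Where it says the series, first, only, none or still open, it means among the compounds named here.

Compound 1 `Cc1ccc2nc([C@H](CC3CCN(CC(C)C)CC3)N3C(=O)CN(c4ccc(Oc5ccccc5)cc4)C3=O)n(C)c2c1` gives 6900 nM in a functional assay on Hep 3B2 cells (Homo sapiens) for cytotoxicity, read by MTT assay; on this read-out higher numbers stand for weaker inhibition and lower numbers for stronger inhibition. Compound 2 `Cc1ccc2nc([C@H](CC3CCN(C(=O)C(C)C)CC3)N3C(=O)CN(c4ccc(Oc5ccccc5)cc4)C3=O)n(C)c2c1` reads > 100000 nM, which is a limit of the assay and not a number. Compound 3 `Cc1ccc2nc([C@H](CC3CCN(C(=O)C4CCCC4)CC3)N3C(=O)CN(c4ccc(Oc5ccccc5)cc4)C3=O)n(C)c2c1` differs from compound 2 by cyclopentyl in place of isopropyl on a carbonyl carbon, with cyclopentyl in place of isopropyl on a carbonyl carbon. Among the compounds with values here, the one measured step, an at least 14-fold higher number from compound 1 to compound 2 (1.16 log units; beyond the scatter), is large, but it put isopropylcarbonyl in place of isobutyl on an amine nitrogen in a ring, and compound 3 keeps the carbonyl. No change beyond the scatter is therefore expected in this assay, and the estimated step is a number no higher from compound 2 to compound 3 (the limit leaves the size open). The estimate for compound 3 is 100000 nM, with an expected range of 30000 nM to 300000 nM.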

Compound 3, half-maximal inhibitory concentration: > 100000 nM
Compound 3: a limit, no number; the forecaster's own chance of this, stated with the estimate: 65%; the middle value sits exactly at the limit.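

In this assay, compound 3 shows that the large step is not confined to isopropylcarbonyl: cyclopentylcarbonyl on the amine nitrogen in a ring gives an at least 14-fold higher number from compound 1 to compound 3 (1.16 log units; beyond the scatter), and its reading is a limit, not a number. With a larger group and a ring on the carbonyl carbon, the reading stays at that limit, and the step from compound 2 to compound 3 cannot be read because both compounds sit there: the limit of > 100000 nM in this assay, at which 2 of the 3 values shown sit.

On these data alone, whether a benzyl group or a longer chain in place of isobutyl would keep a measurable reading remains open. So does the reading with a free amine hydrogen on that nitrogen.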